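From carbamoyl to cyano on a shared core

The compounds below may be only part of what the source reports. "The series", "measured", "known", "first", "only" and "open" are said of these compounds alone.

In a functional assay on the whole organism for inhibition, with Cavia porcellus as the target (on this read-out higher numbers stand for an effect only at larger amounts of compound and lower numbers for an effect already at smaller amounts), compound 3 `NC(=O)c1cn2ccncc2n1` gives > 56 nM, which is a limit and not a number. Compound 1 `COC(=O)c1cn2ccncc2n1` gives > 34 nM, also a limit. Compound 2 `OCc1cn2ccncc2n1` gives > 200 nM, again a limit. Compound 4 `N#Cc1cn2ccncc2n1`, not yet measured, has cyano in place of carbamoyl on an aromatic carbon. The measured steps offer no size to build on: a step that the two limits leave unreadable from compound 2 to compound 3, a step that the two limits leave unreadable from compound 1 to compound 3 and a step that the two limits leave unreadable from compound 1 to compound 2. No step beyond the usual scatter is therefore expected in this assay, and no direction can be given. The estimated step is a step that the limit leaves unreadable from compound 3 to compound 4. For compound 4 the expected value is 80 nM, with an estimated range of 25 nM to 300 nM.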

Compound 4, concentration for half-maximal effect: > 167 nM
Compound 4 ended at the assay's limit; the forecaster's own chance of this, stated with the estimate: 85%; at least 2.0-fold (0.31 log units) between middle value and limit.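

Within the data shown here, compound 4, like compound 1, compound 2 and compound 3, gives only a limit in this assay, so no step to compound 4 can be read. The compounds shown leave open whether cyano differs from carbamoyl on the shared core.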